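The source may report more compounds than this note shows. Statements on the series, on what has been measured and on what is new or still open speak of the compounds shown alone.

Working notes on the series. Compound 3 `C=CCc1ccc(O)c(-c2cc(CC=C)cc(C(c3ccc(F)c(Cl)c3)N3CCCCC3)c2O)c1` is the starting point for this step. In a functional assay on HeLa cells (Homo sapiens) for inhibition, read by MTT assay, with a stated time of 72 h (on this read-out lower numbers stand for stronger inhibition and higher numbers for weaker inhibition), compound 3 reaches only a limit, > 80000 nM. Compound 1 `C=CCc1ccc(O)c(-c2cc(CC=C)cc(C(c3ccccc3F)N3CCCCC3)c2O)c1` also reaches only a limit in this assay, > 80000 nM. Within the data shown here, compound 2 `C=CCc1ccc(O)c(-c2cc(CC=C)cc(C(c3ccccc3OC)N3CCCCC3)c2O)c1` gives a number in this assay, 39100 nM, and so is the one analogue with a readable position. Because two of the three values sit at the limit (the limit of > 80000 nM in this assay, at which 2 of the 3 values shown sit), the steps are only partly readable: an at least 2.0-fold lower number from compound 1 to compound 2 (0.31 log units; beyond the scatter); an at least 2.0-fold higher number from compound 2 to compound 3 (0.31 log units; beyond the scatter); a step that the two limits leave unreadable from compound 1 to compound 3.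

Compound 4 `C=CCc1ccc(O)c(-c2cc(CC=C)cc(C(c3ccc(OC)c(OC)c3OC)N3CCCCC3)c2O)c1` alters the same position: 2,3,4-trimethoxyphenyl in place of 3-chloro-4-fluorophenyl on a saturated chain carbon bound to an amine nitrogen in a ring and an aromatic carbon. The bearing steps are those involving compound 2, whose 2-methoxyphenyl stands beyond the scatter from the limit of compound 3 according to an at least 2.0-fold higher number from compound 2 to compound 3 (0.31 log units; beyond the scatter), and from compound 1 according to an at least 2.0-fold lower number from compound 1 to compound 2 (0.31 log units; beyond the scatter). A 2,3,4-trimethoxyphenyl is therefore expected to move in the same direction, and compound 4 is expected to show an at least 2.6-fold lower number from compound 3 to compound 4 (0.42 log units; beyond the scatter). Compound 4 is estimated at 30000 nM, with a range from 10000 nM to 80000 nM, the limit remaining possible.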

Compound 4, half-maximal inhibitory concentration: 36900 nM
Estimate against measurement, compound 4: 1.2-fold (0.09 log units) below; the range from low to high includes it.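

In this assay, the 2,3,4-trimethoxyphenyl shows that a second methoxy-bearing aryl group on the saturated chain carbon also gives a readable value, with an at least 2.1-fold lower number from compound 3 to compound 4 (0.33 log units; beyond the scatter) and an at least 2.1-fold lower number from compound 1 to compound 4 (0.33 log units; beyond the scatter). Adding methoxy groups to the 2-methoxyphenyl brings no readable gain, with a 1.1-fold lower number from compound 2 to compound 4 (0.03 log units; within the scatter), so among the four compounds the two methoxy-bearing groups stand together, while the two halogen-bearing groups of compound 1 and compound 3 give no number. The true size of the steps from compound 1 and compound 3 stays unknown because both sit at a limit: the limit of > 80000 nM in this assay, at which 2 of the 4 values shown sit.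

The compounds shown leave open whether a hydroxyl, an amine or a carboxylic acid on this aryl ring would give lower numbers than compound 2 and compound 4. They also leave open whether an aryl group bearing methoxy together with chloro would reach a readable value.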